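Acetyl substitution on the distal ring of compound 2

The compounds below may be only part of what the source reports. "The series", "measured", "known", "first", "only" and "open" are said of these compounds alone.

Two compounds of the series have been run in an assay on cells for displacement of a labelled ligand from prostaglandin E2 receptor EP4 subtype (Homo sapiens), read by scintillation counting; a lower number here means a stronger inhibitor, a higher number a weaker inhibitor. Compound 1 `CC(=O)c1ccc(-c2ccc(OCc3cc(C(=O)O)oc3C)cc2)cc1` carries a carboxylic acid together with an acetyl group; in this assay compound 1 gives 150 nM. Compound 2 `Cc1oc(C(=O)NS(=O)(=O)c2ccccc2)cc1COc1ccc(-c2ccccc2)cc1` carries an acylsulfonamide and no acetyl group; in this assay compound 2 gives 25 nM, the lowest of the two numbers, and the gap to compound 1 lies beyond the scatter. For the measured compounds named here, the two measured compounds differ in two places at once, so no single step between them is isolated, and what the acetyl group alone contributes cannot be read from them.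

Compound 3 `CC(=O)c1ccc(-c2ccc(OCc3cc(C(=O)NS(=O)(=O)c4ccccc4)oc3C)cc2)cc1` is the next compound to be measured in this assay. It differs from compound 2 in one place: acetyl in place of hydrogen on an aromatic carbon. Compound 3 thus combines the acylsulfonamide of compound 2 with the acetyl group of compound 1. Going by the values given here, with no isolated step to lean on, the expected step from compound 2 to compound 3 is small, toward a lower number or none beyond the scatter, a 1.7-fold lower number from compound 2 to compound 3 (0.22 log units; within the scatter). The estimate for compound 3 in this assay is 15 nM, within the range 5 nM to 50 nM.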

Compound 3, inhibition constant: 20 nM
For compound 3 the middle estimate is 1.3-fold (0.12 log units) below the measured one; measured number inside the range.
By their numbers in this assay, from the lowest: compounds 3 and 2 (each within the scatter of the next); then compound 1.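

In this assay the phenyl to 4-acetylphenyl change reads as a 1.3-fold lower number from compound 2 to compound 3 (0.10 log units; within the scatter) and so does not separate the two compounds: with the acylsulfonamide in place, this position on the distal ring accepts acetyl with no loss that can be measured. With the acetyl group held constant, (phenylsulfonyl)amino in place of hydroxy on the carbonyl carbon now stands alone as a 7.5-fold lower number from compound 1 to compound 3 (0.88 log units; beyond the scatter) and, of the two single changes read here, is the only one beyond the scatter. Nothing measured alongside these numbers bears on why either step has its size.

The compounds shown leave open whether this tolerance belongs to acetyl alone or extends to other groups at the same place, such as an amine, a carboxylic acid or a longer acyl chain. They also leave open how much the phenyl on the sulfonyl contributes, which a methyl group or a substituted phenyl in its place would begin to show.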